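Notes on the shared core: trifluoromethyl in place of hydrogen

This account rests on a few compounds, and the source may have more. Where it says the series, first, only, none or still open, it means among the compounds named here.

Measured compounds:
Compound 1, `Cc1ccc(N2CC[C@@H](NC(=O)Nc3ccccc3Br)C2)nc1`: in a functional assay for antagonist activity at transient receptor potential cation channel subfamily V member 1 (Rattus norvegicus), read by FLIPR (on this read-out lower numbers stand for lower potency and higher numbers for higher potency (the scale is a negative logarithm)), compound 1 gives only a limit, < 6.7.
Compound 2, `O=C(Nc1ccccc1Br)N[C@@H]1CCN(c2ccccn2)C1`: in this assay compound 2 gives only a limit, < 6.6.
Compound 3, `O=C(Nc1ccccc1Br)N[C@@H]1CCN(c2ccc(Br)cn2)C1`: in this assay compound 3 gives 7.2.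

Compound 2 thus stands at a limit of this assay and not at a number, as the limit of < 6.6 in this assay, at which 1 of the 3 values shown sits, records. Compound 4, `O=C(Nc1ccccc1Br)N[C@@H]1CCN(c2ncccc2C(F)(F)F)C1`, is not yet measured; it differs from compound 2 in trifluoromethyl in place of hydrogen on an aromatic carbon. Among the measured compounds shown here, the only measured step out of compound 2 is a number at least 0.60 log units higher from compound 2 to compound 3 (beyond the scatter); the same bromo group gave a number at least 0.50 log units higher from compound 1 to compound 3 (beyond the scatter), while a step that the two limits leave unreadable from compound 1 to compound 2. A rise beyond the scatter is therefore expected for compound 4, though the entering group is not the one measured. The expected step is a number at least 0.40 log units higher from compound 2 to compound 4 (beyond the scatter). Compound 4 is estimated at 7, within 6.3 to 7.7.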

Compound 4, negative logarithm of the antagonist equilibrium constant: 7.1
Compound 4: the middle estimate sits 0.10 log units below what was measured; measured number inside the range.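

Placing trifluoromethyl on the aromatic carbon ortho to a large group, two atoms from the ring nitrogen, gives a number at least 0.50 log units higher from compound 2 to compound 4 (beyond the scatter). Among the compounds shown here, this carbon carries hydrogen in compound 1, compound 2 and compound 3, so compound 4 is the first to show that a substituent here can raise the number. The step has no upper bound, since compound 2 gives only a limit: the limit of < 6.6 in this assay, at which 1 of the 4 values shown sits.

On these data alone, its full size therefore stays open. So does whether a smaller group such as methyl, or an amine or a carboxylic acid, on this same carbon would give a comparable rise.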